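A Fluoro for Methyl Swap on Compound 3

The source may hold more compounds than are shown below. What is called first, only, known or untested is meant among the compounds shown, and "the series" means these compounds.

Measured in a functional assay (plasma) for inhibition, with Homo sapiens as the target; on this read-out lower numbers stand for stronger inhibition and higher numbers for weaker inhibition:
Compound 1 `Cc1ccc(S(=O)(=O)N[C@H]2CC/C(=N\OCC3CCCCC3)[C@@H]2C/C=C\CCCC(=O)O)cc1`: 600 nM
Compound 2 `O=C(O)CC/C=C\C[C@@H]1[C@@H](NS(=O)(=O)c2ccc(Cl)cc2)CC[C@@H]1O`: 1800 nM
Compound 3 `Cc1ccc(S(=O)(=O)N[C@H]2CC/C(=N\OCc3ccc(C(F)(F)F)cc3)[C@@H]2C/C=C\CCCC(=O)O)cc1`: 180 nM

Compound 3 has the lowest number of these three, so it shows the strongest inhibition in this assay. The next compound, compound 4 `O=C(O)CCC/C=C\C[C@H]1/C(=N/OCc2ccc(C(F)(F)F)cc2)CC[C@@H]1NS(=O)(=O)c1ccc(F)cc1`, has not yet been measured. It departs from compound 3 in a single place: fluoro in place of methyl on an aromatic carbon. This is fluoro in place of methyl on an aromatic carbon, para to a large group, so that 4-methylphenyl becomes 4-fluorophenyl.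

Within the data shown here, only one measured step changes a single group, and it lies elsewhere in the molecule: a 3.3-fold lower number from compound 1 to compound 3 (0.52 log units; beyond the scatter), a modest step that puts 4-(trifluoromethyl)phenyl in place of cyclohexyl. It shows that a single swap can move the number, but it says little about this one. Compared with compound 3, compound 2 differs in more than one place, so its 1800 nM does not isolate this swap either. Among the measured compounds shown here, no measured pair tests the methyl-to-fluoro change directly, so no clear direction can be expected. The expected change, no change at the digits printed from compound 3 to compound 4 (within the scatter), is therefore estimated to stay within the usual scatter. For compound 4 the expected value is 180 nM, with an estimated range from 70 nM to 450 nM.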

Compound 4, half-maximal inhibitory concentration: 620 nM
For compound 4 the middle estimate is 3.4-fold (0.54 log units) below the measured one, and the stated range ends below it.
By their numbers in this assay, from the lowest: compound 3; then compounds 1 and 4 (each within the scatter of the next); then compound 2.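

Swapping methyl for fluoro, so that 4-methylphenyl becomes 4-fluorophenyl, gives a 3.4-fold higher number from compound 3 to compound 4 (0.54 log units; beyond the scatter) in this assay and so weakens inhibition. Among these compounds, the only earlier single-place step, a 3.3-fold lower number from compound 1 to compound 3 (0.52 log units; beyond the scatter), changed the other end of the molecule, so this is the first evidence that the aromatic carbon on the sulfonyl side also affects the number, even though the exchange is only one heavy atom for one heavy atom, with no change in the counted hydrogen-bond donors or acceptors. No measurement available here explains why this exchange weakens inhibition.

Going by these compounds, whether methyl is especially favourable or fluoro especially unfavourable remains open, since only these two groups have been compared on this scaffold, and a plain hydrogen, a methoxy group or a nitrile at the same aromatic carbon would help separate the two readings. On these data alone, it is also open whether the same swap would move the number in the same direction and by a similar amount if cyclohexyl replaced 4-(trifluoromethyl)phenyl at the other end of the molecule.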